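Thiazolyl for Pyridyl on the Urea Nitrogen of Two Cores

The source may hold more compounds than are shown below. What is called first, only, known or untested is meant among the compounds shown, and "the series" means these compounds.

Compound 1, `O=C(Nc1ccncc1)Nc1cc(-c2cncnc2)cc(C(F)(F)F)c1`, gives 2420 nM. Compound 3, `O=C(Nc1cc(-c2cncnc2)cc(C(F)(F)F)c1)Nc1nccs1`, gives 18300 nM. Compound 2, `COc1ccc(-c2ccc(OC(F)(F)F)c(NC(=O)Nc3ccncc3)c2)cn1`, is reported only as a limit, > 300000 nM.

All three were examined in a functional assay on A549 cells (Homo sapiens) for inhibition, read by MTT assay, with a stated time of 48 h; on this read-out higher numbers stand for weaker inhibition and lower numbers for stronger inhibition. Compound 1 and compound 3 share a core and differ in one place: 1,3-thiazol-2-yl in place of pyridin-4-yl on an amide-type nitrogen. This change produced a 7.6-fold higher number from compound 1 to compound 3 (0.88 log units; beyond the scatter), a worsening that lies beyond the usual scatter of the assay. The difference between the core of compound 1 and the core of compound 2 is not broken down here.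

Compound 4, `COc1ccc(-c2ccc(OC(F)(F)F)c(NC(=O)Nc3nccs3)c2)cn1`, has not yet been measured in this assay. It differs from compound 2 by the same change made between compound 1 and compound 3: 1,3-thiazol-2-yl in place of pyridin-4-yl on an amide-type nitrogen. The place of the change is described in the same words for both pairs, so it is the same change on a different core.

Since the measured step in this assay ran toward weaker inhibition, and since compound 2 already stands at a limit because of the limit of > 300000 nM in this assay, at which 1 of the 3 values shown sits, compound 4 is expected to remain at or beyond that limit, so that the step that the limit leaves unreadable from compound 2 to compound 4 is an estimate rather than a measurable difference. The estimate for compound 4 in this assay is 600000 nM, with a range from 200000 nM to 3000000 nM.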

Compound 4, half-maximal inhibitory concentration: 35000 nM
Estimate against measurement, compound 4: 17-fold (1.23 log units) above, and the stated range ends above it.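

In this assay, placing 1,3-thiazol-2-yl where pyridin-4-yl stood on the amide-type nitrogen gave an at least 8.5-fold lower number from compound 2 to compound 4 (0.93 log units; beyond the scatter), so the direction seen on the core of compound 1 did not carry over to the core of compound 2. Set side by side, the two steps run in opposite directions, and the gap between them is larger than the scatter allows: the same change on two cores in this assay, a 7.6-fold higher number (0.88 log units; beyond the scatter) from compound 1 to compound 3 and an at least 8.5-fold lower number (0.93 log units; beyond the scatter) from compound 2 to compound 4, at least 64-fold (1.81 log units) apart, beyond the scatter of two such steps The two pairs do not show which part of the cores reverses the change, and the size of the second step stays open at one end, compound 2 being held at a limit: the limit of > 300000 nM in this assay, at which 1 of the 4 values shown sits.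

The compounds shown leave open where along the way from the core of compound 1 to the core of compound 2 the reversal arises, since no core here carries only part of that difference. They also leave open how other groups on the same nitrogen, such as a plain phenyl ring or a 1,3-oxazol-2-yl ring, would behave on these two cores, and so whether the opposite outcome belongs to the thiazole alone.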